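A few compounds are considered here, and "the series" means these few. Any claim that something is new, unique, unknown or untested is made for them only; others in the source may bear on it.

Measured in a functional assay on LOX IMVI cells (Homo sapiens) for inhibition, read by sulforhodamine B assay, with a stated time of 48 h, tested at 10 uM; a lower number here means a stronger effect, a higher number a weaker effect of the compound at the concentration tested:
compound 1 `COc1cc(Cl)cc(-c2nn(-c3cccc(NC(=O)Nc4cccc(C(F)(F)F)c4)c3)cc2-c2ccncc2)c1` — 4.64%
compound 2 `COc1cc(Cl)cc(-c2nn(-c3cccc(NC(=O)Nc4ccc(Cl)c(C(F)(F)F)c4)c3)cc2-c2ccncc2)c1` — 4.81%
compound 3 `COc1cc(Cl)cc(-c2nn(-c3cccc(NC(=O)c4cccc(C(F)(F)F)c4)c3)cc2-c2ccncc2)c1` — 51.7%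

On these numbers compound 3 stands highest, beyond the scatter from compound 2 and from compound 1, so its effect in this assay is the weakest of the three. Compound 4 `COc1cc(Cl)cc(-c2nn(-c3cccc(NC(=O)Nc4ccc(Cl)c(Cl)c4)c3)cc2-c2ccncc2)c1` is not yet measured; it differs from compound 3 in one place: (3,4-dichlorophenyl)amino in place of 3-(trifluoromethyl)phenyl on a carbonyl carbon. The measured steps that bear on this are the reverse of a number 47.1 percentage points higher from compound 1 to compound 3 (beyond the scatter) and of a number 46.9 percentage points higher from compound 2 to compound 3 (beyond the scatter), both large, while a number 0.2 percentage points higher from compound 1 to compound 2 (within the scatter) shows that the chloro on the aryl ring of the urea barely matters. The step from compound 3 to compound 4 is therefore expected to be large and downward, a number 45.7 percentage points lower from compound 3 to compound 4 (beyond the scatter). Compound 4 is estimated at 6%, range 0% to 20%.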

Compound 4, a percentage reported as activity, at one concentration (the size of the read-out at that concentration, not a potency): 9.24%
Compound 4: the middle estimate sits 3.2 percentage points below what was measured; the range from low to high includes it.
By their numbers in this assay, from the lowest: compounds 1, 2 and 4 (each within the scatter of the next); then compound 3.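

In this assay the urea link again outperforms the amide, now with a different aryl ring: a number 42.5 percentage points lower from compound 3 to compound 4 (beyond the scatter) when (3,4-dichlorophenyl)amino enters on the carbonyl carbon. Trifluoromethyl is not required on the urea aryl ring, as the values stay level with chloro in its place, a number 4.4 percentage points higher from compound 2 to compound 4 (within the scatter) and with 3,4-dichlorophenyl replacing 3-(trifluoromethyl)phenyl, a number 4.6 percentage points higher from compound 1 to compound 4 (within the scatter) on the amide-type nitrogen. Nothing available explains these differences.

Still open, going by these compounds, is whether a nitrile or a dimethylamino group on that aryl ring would hold the effect. Also open, on these data alone, is whether 3,4-dichlorophenyl directly on the carbonyl carbon would lose as much as compound 3 does.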